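Replacing bromo with benzoyl on the shared core

The compounds below may be only part of what the source reports. "The series", "measured", "known", "first", "only" and "open" are said of these compounds alone.

In a functional assay for inhibition, with Rattus norvegicus as the target (a higher number here means a weaker inhibitor, a lower number a stronger inhibitor), three compounds on one core differ only in a single group on an aromatic carbon. Compound 1 `Cc1cc(C#N)ccc1/N=c1\c(O)c(O)\c1=N/[C@H](C)C(C)(C)C` carries methyl and gives 1080 nM. Compound 2 `C[C@@H](/N=c1\c(O)c(O)\c1=N/c1ccc(C#N)cc1O)C(C)(C)C` carries hydroxy and gives 6050 nM. Compound 3 `C[C@@H](/N=c1\c(O)c(O)\c1=N/c1ccc(C#N)cc1Br)C(C)(C)C` carries bromo and gives 75 nM, the lowest number of the three and so the strongest inhibitor among them.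

Compound 4 `C[C@@H](/N=c1\c(O)c(O)\c1=N/c1ccc(C#N)cc1C(=O)c1ccccc1)C(C)(C)C` has not yet been measured. It has benzoyl in place of bromo on an aromatic carbon.

Among the compounds with values here, the only guides are the steps among the three measured groups. There is a 14-fold lower number from compound 1 to compound 3 (1.16 log units; beyond the scatter), then an 81-fold lower number from compound 2 to compound 3 (1.91 log units; beyond the scatter), and a 5.6-fold higher number from compound 1 to compound 2 (0.75 log units; beyond the scatter). Both methyl in compound 1 at 1080 nM and hydroxy in compound 2 at 6050 nM sit above bromo, though neither resembles benzoyl, so the direction is only tentatively supported. A rise of modest to large size is therefore expected in this assay. The estimated change is an 8.0-fold higher number from compound 3 to compound 4 (0.90 log units; beyond the scatter). Compound 4 is expected at 600 nM, with an estimated range of 120 nM to 3000 nM.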

Compound 4, half-maximal inhibitory concentration: 4780 nM
Estimate against measurement, compound 4: 8.0-fold (0.90 log units) below, and the stated range ends below it.
By their numbers in this assay, from the lowest: compound 3; then compound 1; then compounds 4 and 2 (each within the scatter of the next).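

In this assay, the change from bromo to benzoyl gives a 64-fold higher number from compound 3 to compound 4 (1.80 log units; beyond the scatter), showing that a much larger group with its own aromatic ring is far from equivalent to bromo at this position. Benzoyl also compares poorly with the small methyl group, with a 4.4-fold higher number from compound 1 to compound 4 (0.65 log units; beyond the scatter), so the number at this position does not fall simply as the group grows. Benzoyl and hydroxy cannot be told apart, with a 1.3-fold lower number from compound 2 to compound 4 (0.10 log units; within the scatter), even though they are very different groups.

As far as these compounds go, whether the rise belongs to the carbonyl or to the added ring remains open, as does whether chloro or iodo, or a plain phenyl or benzyl group, would match bromo. Nothing available here explains the behaviour of benzoyl at this position.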